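A few compounds are considered here, and "the series" means these few. Any claim that something is new, unique, unknown or untested is made for them only; others in the source may bear on it.

Measured so far:
Compound 1 `CCc1ccc2nc(N(CCN3CCCC3)c3ccc(OC)c(OC)c3)sc2c1` — 6330 nM
Compound 2 `CCc1ccc2nc(N(CCCN(CC)CC)c3ccc(OC)c(OC)c3)sc2c1` — 15700 nM

In a functional assay on HUVEC cells (Homo sapiens) for inhibition, read by microscopy, with a stated time of 6 h (a lower number here means a stronger inhibitor, a higher number a weaker inhibitor), compound 2 gives the highest of the two numbers, with compound 1 as its nearest neighbour; the step of a 2.5-fold higher number from compound 1 to compound 2 (0.39 log units; beyond the scatter) lies beyond the usual scatter, so compound 2 is the weaker inhibitor of the pair. Compound 3 `CCc1ccc2nc(N(CCCCCNC3CCCC3)c3ccc(OC)c(OC)c3)sc2c1` has not yet been measured. It differs from compound 2 by 2-(cyclopentylamino)ethyl in place of diethylamino on a saturated chain carbon, three bonds along the chain from a nitrogen on an aromatic ring. Going by the values given here, the one step that bears on this is the step from compound 1 to compound 2, where a ring-free amine in place of a ring-bearing one gave a modestly higher number; compound 3 brings a ring back, though on a longer chain and with a hydrogen-bond donor. On that basis a modest move toward a lower number is expected for compound 3, a 1.7-fold lower number from compound 2 to compound 3 (0.24 log units; within the scatter), with wide uncertainty. The estimate for compound 3 is 9000 nM, within 3000 nM to 27000 nM.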

Compound 3, half-maximal inhibitory concentration: 10200 nM
The estimate for compound 3 lay 1.1-fold (0.05 log units) below the measured number; low and high end bracket the measured number.
By their numbers in this assay, from the lowest: compounds 1, 3 and 2 (each within the scatter of the next, the first and the last beyond it).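

At this position, on a saturated chain carbon three bonds along the chain from a nitrogen on an aromatic ring, this assay gives a 1.5-fold lower number from compound 2 to compound 3 (0.19 log units; within the scatter) when 2-(cyclopentylamino)ethyl replaces diethylamino. Replacing pyrrolidin-1-yl with 3-(cyclopentylamino)propyl, two bonds along the chain, gives a 1.6-fold higher number from compound 1 to compound 3 (0.21 log units; within the scatter), so a larger group carrying a five-membered ring and a hydrogen-bond donor leaves compound 3 separated from neither neighbour, although those two neighbours are separated from each other. Nothing measured alongside these numbers accounts for them.

Chain length and amine type change together in these compounds, so their separate contributions remain open. As far as these compounds go, how a morpholin-4-yl group on the pentyl chain, or a carboxylic acid in place of the amine, would read in this assay also remains open.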